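From 4-Methylphenyl to 2-Chlorophenyl: A Small Step Expected

This account rests on a few compounds, and the source may have more. Where it says the series, first, only, none or still open, it means among the compounds named here.

In an ADME assay on HUVEC cells (Homo sapiens) for inhibition, read by CCK-8 assay, with a stated time of 24 h, in the presence of a further agent that is not named here (a higher number here means a weaker inhibitor, a lower number a stronger inhibitor), compound 1 (`O=C1Nc2ccccc2/C1=C/c1ccc(-c2cn(-c3ccccc3F)nn2)cc1`) gives 19300 nM and compound 2 (`Cc1ccc(-n2cc(-c3ccc(/C=C4\C(=O)Nc5ccc(F)cc54)cc3)nn2)cc1`) gives 13800 nM. These two numbers lie within the usual scatter of repeated measurements, so compound 2 cannot be ranked apart from compound 1.

The next molecule, compound 3 (`O=C1Nc2ccc(F)cc2/C1=C/c1ccc(-c2cn(-c3ccccc3Cl)nn2)cc1`), differs from compound 2 in one place: 2-chlorophenyl in place of 4-methylphenyl on an aromatic nitrogen. Within the data shown here, no measured pair here differs in only one place, so there is no direct precedent for this swap. Among the measured compounds shown here, the only guide is that compound 1, at 19300 nM, and compound 2, at 13800 nM, stay close although they differ in more than one place. In this assay, no change beyond the scatter is therefore expected, in either direction, and the estimate is a 1.1-fold higher number from compound 2 to compound 3 (0.04 log units; within the scatter). For compound 3 the expected value is 15000 nM, with an estimated range of 7000 nM to 32000 nM.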

Compound 3, half-maximal inhibitory concentration: 18200 nM
Compound 3: middle estimate off by 1.2-fold (0.08 log units), on the low side; measured number inside the range.
By their numbers in this assay, from the lowest: compounds 2, 3 and 1 (each within the scatter of the next).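

In this assay the swap to 2-chlorophenyl in place of 4-methylphenyl on the aromatic nitrogen gives a 1.3-fold higher number from compound 2 to compound 3 (0.12 log units; within the scatter), so the two groups cannot be told apart. This is the only pair shown that differs in one place, and it gives this position a direct reading: exchanging one substituted phenyl for the other, with a different substituent in a different place on the ring, leaves no change that can be separated from the scatter. No measurement shown offers an explanation for this result.

Every group shown at this position is a phenyl ring carrying one substituent, so it remains open whether an amine, a carboxylic acid or a longer chain there would shift the number beyond the scatter. Among these compounds, the role of the fluorine on the core also stays unresolved, since no pair differs there alone.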